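Branching the side chain of a small ester series

The compounds below may be only part of what the source reports. "The series", "measured", "known", "first", "only" and "open" are said of these compounds alone.

Measured compounds and their values:
Compound 1, `O=C(CN(c1ncnc2c1ncn2C1CCCCO1)C1CC1)N[C@@H](CCC(=O)OCc1ccccc1)C(=O)OCc1ccccc1`, gives 32.6%.
Compound 2, `CC[C@H](C)[C@H](NC(=O)CN(c1ncnc2c1ncn2C1CCCCO1)C1CC1)C(=O)OCc1ccccc1`, gives 25.6%.
Compound 3, `C[C@H](NC(=O)CN(c1ncnc2c1ncn2C1CCCCO1)C1CC1)C(=O)OCc1ccccc1`, gives 55.9%.

These three compounds share one core and differ only in the group on the saturated chain carbon bound to an amide-type nitrogen and a carbonyl carbon. In a functional assay on the whole organism (Tail, strain ICR) with Mus musculus as the target, in the tail flick test, with a stated time of 30 min, at a dose of 25 umol/kg by the oral route (a lower number here means a weaker effect, a higher number a stronger effect of the compound at the dose given), compound 3 stands highest of the three numbers; the nearest is compound 1, which lies beyond the scatter below it, and the furthest is compound 2.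

Compound 4, `CC(C)[C@H](NC(=O)CN(c1ncnc2c1ncn2C1CCCCO1)C1CC1)C(=O)OCc1ccccc1`, has not yet been measured. It differs from compound 3 in one place: isopropyl in place of methyl on a saturated chain carbon bound to an amide-type nitrogen and a carbonyl carbon.

The step that bears most on this change is a number 30.3 percentage points higher from compound 2 to compound 3 (beyond the scatter), where a larger branched group gave way to methyl and the read-out rose strongly. The step of a number 7 percentage points lower from compound 1 to compound 2 (within the scatter) was within the scatter. Isopropyl is a branched group smaller than sec-butyl, so part of that large step is expected to reverse: a downward step in this assay of a number 17.9 percentage points lower from compound 3 to compound 4 (beyond the scatter) is expected, landing between the values of compound 1 and compound 3. Compound 4 is therefore estimated at 38%, with a range from 22% to 54%.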

Compound 4, a percentage reported as activity, at one dose (the size of the read-out at that dose, not a potency): 21.8%
For compound 4 the middle estimate is 16.2 percentage points above the measured one; measured number outside the range, below it.
By their numbers in this assay, from the lowest: compounds 4, 2 and 1 (each within the scatter of the next, the first and the last beyond it); then compound 3.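

In this assay the isopropyl group takes the read-out down as far as the larger sec-butyl group did: the change from methyl gives a number 34.1 percentage points lower from compound 3 to compound 4 (beyond the scatter) and trimming sec-butyl gives a number 3.8 percentage points lower from compound 2 to compound 4 (within the scatter), so at this carbon the smaller branched group recovers nothing. Replacing the 2-(benzyloxycarbonyl)ethyl group with isopropyl gives a number 10.8 percentage points lower from compound 1 to compound 4 (beyond the scatter), which leaves methyl as the only group shown that stands clearly apart from all the others. No measurement here says why this position responds in this way.

The compounds shown leave open whether the read-out falls gradually or abruptly between methyl and isopropyl, since an ethyl or an unbranched propyl group at this carbon would be needed to tell. They also leave open what a plain hydrogen here would do, or a free carboxylic acid in place of the benzyl ester.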